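The source may hold more compounds than are shown below. What is called first, only, known or untested is meant among the compounds shown, and "the series" means these compounds.

Measured compounds:
compound 1 `CCOC(=O)c1cn(C(c2ccccc2)c2cc3cc(Br)ccc3nc2OC)nn1` — 16.1%
compound 2 `COc1nc2ccc(Br)cc2cc1C(c1ccccc1)n1cc(-c2ccc(OC(F)(F)F)cc2)nn1` — 21.6%

In an ADME assay on PC-3 cells (Homo sapiens) for cytotoxicity, read by sulforhodamine B assay, with a stated time of 48 h, tested at 10 uM (on this read-out lower numbers stand for less inhibition and higher numbers for more inhibition at the one concentration tested (going by the name of the read-out)), compound 1 gives 16.1% and compound 2 gives 21.6%. Within the data shown here, compound 2 holds the higher of the two numbers, but the only measured step, a number 5.5 percentage points higher from compound 1 to compound 2 (within the scatter), lies within the scatter, so the two compounds cannot be set apart on these data.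

Compound 3 `COc1nc2ccc(Br)cc2cc1C(c1ccccc1)n1cc(-c2ccc(F)cc2)nn1` is not yet measured in this assay. It differs from compound 2 by fluoro in place of trifluoromethoxy on an aromatic carbon.

Among the measured compounds shown here, no measured step matches this change. For the measured compounds named here, the one step available, a number 5.5 percentage points higher from compound 1 to compound 2 (within the scatter), exchanges the whole group on the shared core and was itself within the scatter, so it offers no direction for an exchange inside the 4-(trifluoromethoxy)phenyl group. Both measured numbers sit in a narrow band near the lower end of the read-out, and there is no reason from these data to expect compound 3 to leave that band.

Compound 3 is therefore estimated at 19%, with a range from 7% to 31%, which means an expected step of a number 2.6 percentage points lower from compound 2 to compound 3 (within the scatter), not beyond the scatter.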

Compound 3, a percentage reported as inhibition, at one concentration (the size of the read-out at that concentration, not a potency): 16.4%
The estimate for compound 3 lay 2.6 percentage points above the measured number; the range from low to high includes it.
By their numbers in this assay, from the lowest: compounds 1, 3 and 2 (each within the scatter of the next).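

Fluoro in place of trifluoromethoxy, on an aromatic carbon para to a large group, gives a number 5.2 percentage points lower from compound 2 to compound 3 (within the scatter), so in this assay this first measured exchange within the aryl substituent cannot be told apart from no change at all. Going from ethoxycarbonyl to 4-fluorophenyl gives a number 0.3 percentage points higher from compound 1 to compound 3 (within the scatter), and this second exchange of the whole group, like the one to 4-(trifluoromethoxy)phenyl, likewise shows no difference that can be read, so neither the ester nor either aryl group can be set apart from the others at this one concentration. There is no supporting measurement that could explain why the three numbers lie so close together.

What the compounds shown leave open is whether any group at this place can move the read-out beyond the scatter, for instance an amine, a carboxylic acid or a longer alkyl chain in place of the ethoxycarbonyl or aryl group. On these data alone, it is also open whether a hydroxyl or a methoxy on the aromatic carbon now holding fluoro would behave any differently, and whether the flat picture holds for changes elsewhere on the shared core, such as at the bromo group.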